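Compound 4: 3-hydroxypiperidin-1-yl for 1H-imidazol-1-yl

This account rests on a few compounds, and the source may have more. Where it says the series, first, only, none or still open, it means among the compounds named here.

Measured so far:
compound 1 `COc1cc[nH]c1/C=C1\C(=O)Nc2ccc([N+](=O)[O-])c(N3CC[C@@H](O)C3)c21`: 88 nM
compound 2 `COc1cc[nH]c1/C=C1\C(=O)Nc2ccc([N+](=O)[O-])c(N[C@H]3CC[C@H](N)C3)c21`: 61 nM
compound 3 `COc1cc[nH]c1/C=C1\C(=O)Nc2ccc([N+](=O)[O-])c(-n3ccnc3)c21`: > 30000 nM

All three were run in a functional assay on MDA-MB-435 cells (Homo sapiens) for antiproliferative activity, read by MTT assay, with a stated time of 5 days; on this read-out higher numbers stand for weaker inhibition and lower numbers for stronger inhibition. Compound 1 and compound 2 both give low numbers, and the move a 1.4-fold lower number from compound 1 to compound 2 (0.16 log units; within the scatter) stays within the scatter. Compound 3 sits at the ceiling of this assay: its value > 30000 nM is a limit, not a number, as recorded in the limit of > 30000 nM in this assay, at which 1 of the 3 values shown sits. The two steps leading to it are large: an at least 340-fold higher number from compound 1 to compound 3 (2.53 log units; beyond the scatter) and an at least 490-fold higher number from compound 2 to compound 3 (2.69 log units; beyond the scatter), so on the numbers shown compound 3 is the one compound without measurable inhibition.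

Compound 4 `COc1cc[nH]c1/C=C1\C(=O)Nc2ccc([N+](=O)[O-])c(N3CCCC(O)C3)c21` is not yet measured in this assay. It differs from compound 3 by 3-hydroxypiperidin-1-yl in place of 1H-imidazol-1-yl on an aromatic carbon. This step reverses the kind of change seen in the two steps above: the 1H-imidazol-1-yl group that accompanied the loss of activity leaves, and a saturated ring carrying a hydroxyl group, close in kind to the 3-hydroxypyrrolidin-1-yl of compound 1, enters at the same aromatic carbon. A large step to lower numbers in this assay is therefore expected, in the order of an at least 200-fold lower number from compound 3 to compound 4 (2.30 log units; beyond the scatter), though the value of compound 3 being only a limit makes its exact size uncertain. Compound 4 is expected to give about 150 nM, within 40 nM to 800 nM.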

Compound 4, half-maximal inhibitory concentration: 250 nM
Estimate against measurement, compound 4: 1.7-fold (0.22 log units) below; low and high end bracket the measured number.
By their numbers in this assay, from the lowest: compounds 2 and 1 (each within the scatter of the next); then compound 4. At a limit, above all of these: compound 3.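

Replacing 1H-imidazol-1-yl with 3-hydroxypiperidin-1-yl on this aromatic carbon, ortho to a nitro group, brings back measurable inhibition in this assay, with an at least 120-fold lower number from compound 3 to compound 4 (2.07 log units; beyond the scatter). The value of compound 3 remains a limit: the limit of > 30000 nM in this assay, at which 1 of the 4 values shown sits.

Within the data shown here, the earlier compounds showed only that two saturated groups at this position gave values within the scatter of each other, whereas the new result shows that the position also separates saturated groups, with a 2.8-fold higher number from compound 1 to compound 4 (0.45 log units; beyond the scatter) and a 4.1-fold higher number from compound 2 to compound 4 (0.61 log units; beyond the scatter), both modest next to the step from the imidazole.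

Still open, from the compounds shown here alone, is whether the hydroxyl group contributes at all, which a plain piperidin-1-yl or pyrrolidin-1-yl group, or a 3-aminopiperidin-1-yl group in its place, would help to settle. Also open, going by these compounds, is whether the loss seen with 1H-imidazol-1-yl extends to other aromatic rings on this carbon, such as a phenyl or pyridyl ring.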